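Replacing a Bromine by an Acetylphenyl Group

The source may hold more compounds than are shown below. What is called first, only, known or untested is meant among the compounds shown, and "the series" means these compounds.

Compound 1 `Brc1cn2ccnc2c(-c2ccc3ncn(C4CCCCC4)c3c2)n1` gives 17.1%
Compound 2 `COc1ccc(-c2cn3ccnc3c(-c3ccc4ncn(C5CCCCC5)c4c3)n2)cc1` gives 49.9%
Compound 3 `Fc1ccc(-c2cn3ccnc3c(-c3ccc4ncn(C5CCCCC5)c4c3)n2)cc1` gives 10.7%

All three compounds were tested in a functional assay on SF-268 cells (Homo sapiens) for inhibition, read by sulforhodamine B assay, with a stated time of 48 h, tested at 10 uM; on this read-out lower numbers stand for less inhibition and higher numbers for more inhibition at the one concentration tested (going by the name of the read-out). Compound 1 stands second highest of the three numbers: its nearest neighbour is compound 3, whose value lies within the scatter of repeated measurements, and its furthest is compound 2, which sits well beyond it.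

Compound 4 `CC(=O)c1ccc(-c2cn3ccnc3c(-c3ccc4ncn(C5CCCCC5)c4c3)n2)cc1` differs from compound 1 in one place: 4-acetylphenyl in place of bromo on an aromatic carbon. Two measured steps start from the same bromo position and bear on this change. Putting a 4-methoxyphenyl group there gave a number 32.8 percentage points higher from compound 1 to compound 2 (beyond the scatter), while a 4-fluorophenyl group gave a number 6.4 percentage points lower from compound 1 to compound 3 (within the scatter). So a phenyl ring carrying a single substituent can leave the inhibition where it was or lift it strongly, and the direction depends on which substituent the ring carries. Among the compounds with values here, the acetyl group resembles neither of these exactly, so the expectation is a rise in this assay that may fall short of the one seen for compound 2. Compound 4 is therefore estimated at 28%, within a range from 5% to 55%, which means an expected step of a number 10.9 percentage points higher from compound 1 to compound 4 (beyond the scatter).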

Compound 4, a percentage reported as inhibition, at one concentration (the size of the read-out at that concentration, not a potency): 5.01%
Estimate against measurement, compound 4: 23 percentage points above, and the stated range covers the measured number.
By their numbers in this assay, from the lowest: compounds 4, 3 and 1 (each within the scatter of the next, the first and the last beyond it); then compound 2.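

In this assay the 4-acetylphenyl group in place of bromo gives a number 12.1 percentage points lower from compound 1 to compound 4 (beyond the scatter) and so shows that a substituted phenyl ring at this position can also lower the number, which neither earlier step showed. On that ring, acetyl in place of fluoro gives a number 5.7 percentage points lower from compound 3 to compound 4 (within the scatter) and leaves the two groups indistinguishable here, whereas acetyl in place of methoxy gives a number 44.9 percentage points lower from compound 2 to compound 4 (beyond the scatter) as the largest step in the set. Adding a phenyl ring therefore does not by itself raise the number, and among these three rings only the methoxy-bearing one in compound 2 stands apart.

An unsubstituted phenyl, or an amine or hydroxyl on the same ring, would help show how far that rise extends. Nothing available explains why methoxy differs from fluoro and acetyl.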